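A few compounds are considered here, and "the series" means these few. Any claim that something is new, unique, unknown or untested is made for them only; others in the source may bear on it.

Three compounds sharing one core were examined in a functional assay on MCF7 cells (Homo sapiens) for antiproliferative activity; on this read-out lower numbers stand for stronger inhibition and higher numbers for weaker inhibition. Compound 1, `C=CCCCn1c(Cc2cc(OC)c(OC)c(OC)c2)nc2c(N)nc(F)nc21`, gives 44700 nM in this assay. Compound 2, `CCCCn1c(Cc2c(Br)c(OC)c(OC)c(OC)c2Br)nc2c(N)ncnc21`, gives 30200 nM. Compound 3, `CC/C=C/Cn1c(Cc2cc(OC)c(OC)c(OC)c2)nc2c(N)ncnc21`, gives 46800 nM, the highest of the three numbers, though its nearest neighbour compound 1 lies within the scatter of it, and so does compound 2, the furthest of the three. On these numbers the three compounds cannot be told apart.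

Compound 4, `COc1cc(Cc2nc3c(N)ncnc3n2CC(OC)OC)cc(OC)c1OC`, has not yet been measured in this assay. It differs from compound 3 in one place: dimethoxymethyl in place of but-1-en-1-yl on a saturated chain carbon bound to an aromatic nitrogen. For the measured compounds named here, no pair of measured compounds shows this change, so there is no measured step to lean on. The three measured compounds vary at the chain on the aromatic nitrogen and at the ring carrying the three methoxy groups, and all three give numbers within the scatter of one another, which gives no reason to expect the new chain to move the number beyond the scatter in either direction. Compound 4 is therefore expected to give about 42000 nM, within a range of 15000 nM to 110000 nM, which would mean an estimated step of a 1.1-fold lower number from compound 3 to compound 4 (0.05 log units; within the scatter).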

Compound 4, half-maximal inhibitory concentration: 72400 nM
Estimate against measurement, compound 4: 1.7-fold (0.24 log units) below; the range from low to high includes it.
By their numbers in this assay, from the lowest: compounds 2, 1, 3 and 4 (each within the scatter of the next, the first and the last beyond it).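

For the compounds shown here, the exchange of but-1-en-1-yl for dimethoxymethyl on a saturated chain carbon bound to an aromatic nitrogen gives a 1.5-fold higher number from compound 3 to compound 4 (0.19 log units; within the scatter) in this assay and is the first measured step at this position in the set. It shows that this position can take a group of 5 heavy atoms with 2 oxygen and 2 hydrogen-bond acceptors, in place of an all-carbon group of 4 heavy atoms with a double bond, and the number still stays within the scatter. Nothing at hand ties this step to a property of either group, so the result can be reported only as a measured step and not explained.

As far as these compounds go, whether an amine, a carboxylic acid or a longer chain at this same position would carry the number beyond the scatter of compound 3 remains open. Also open, from the compounds shown here alone, is whether dimethoxymethyl would read the same with the fluorine of compound 1 or the two bromines of compound 2 elsewhere on the molecule, since a single step on one background cannot say whether the change carries over to another.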